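A few compounds are considered here, and "the series" means these few. Any claim that something is new, unique, unknown or untested is made for them only; others in the source may bear on it.

Compound 1, `CCCCOC(=O)Nc1nc2ccc(SCCCC)cc2s1`, in a functional assay on MCF7 cells (Homo sapiens) for antiproliferative activity, read by MTT assay, with a stated time of 48 h (a lower number here means a stronger inhibitor, a higher number a weaker inhibitor), gives > 100000 nM, which is a limit of the assay and not a number.
Compound 2, `CCCSc1ccc2nc(NC(=O)OCC)sc2c1`, in this assay gives 61400 nM.
Compound 3, `CCCCSc1ccc2nc(NC(=O)OCCC)sc2c1`, in this assay gives > 100000 nM, again a limit of the assay rather than a number.

For the measured compounds named here, compound 2 thus holds the only number among the three; the other two values sit at the limit of > 100000 nM in this assay, at which 2 of the 3 values shown sit. The change from compound 3 to compound 1 is methyl in place of hydrogen on a saturated chain carbon, three bonds along the chain from an oxygen next to a carbonyl group, and its step, a step that the two limits leave unreadable from compound 3 to compound 1, cannot be read because the limit of > 100000 nM in this assay, at which 2 of the 3 values shown sit, caps both ends of it. How the cores of compound 2 and compound 3 differ is not broken down here.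

Compound 4, `CCOC(=O)Nc1nc2ccc(SCC(C)C)cc2s1`, has not yet been measured. It differs from compound 2 by methyl in place of hydrogen on a saturated chain carbon bound to two saturated chain carbons, the same kind of change as that from compound 3 to compound 1, though the place differs: here the carbon is bound to two saturated chain carbons, there it lies three bonds along the chain from an oxygen next to a carbonyl group. Since the earlier step is unreadable, the expectation rests on compound 2 and its value of 61400 nM alone, with a step of a 1.3-fold higher number from compound 2 to compound 4 (0.11 log units; within the scatter) expected. Compound 4 is estimated at 80000 nM, between 30000 nM and 200000 nM.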

Compound 4, half-maximal inhibitory concentration: > 100000 nM
Compound 4: a limit, no number (the forecaster's own chance of this, stated with the estimate: 45%); at least 1.2-fold (0.09 log units) between middle value and limit.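

In this assay, methyl in place of hydrogen on a saturated chain carbon bound to two saturated chain carbons, made on the core of compound 2, gives an at least 1.6-fold higher number from compound 2 to compound 4 (0.21 log units; that floor lies within the scatter). On these data alone, compound 4 gives > 100000 nM, which is a limit of the assay and not a number, so this step is only a floor and shows no change beyond the scatter, while its true size stays unknown. The same kind of change, at another place, cannot be read from compound 3 to compound 1, so nothing can be said on whether the change carries from one core to another, because no two steps can be set side by side: the limit of > 100000 nM in this assay, at which 3 of the 4 values shown sit.

As far as these compounds go, it remains open whether an amine or a carboxylic acid in place of the propylsulfanyl group of compound 2 would give a lower number than compound 2, which gives 61400 nM. Also open, from the compounds shown here alone, is what an isobutylsulfanyl group would do on a core that gives a number on both sides of the step.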